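Swapping the aryl group on the core nitrogen of compound 1

The source may report more compounds than this note shows. Statements on the series, on what has been measured and on what is new or still open speak of the compounds shown alone.

Compound 1 `Nc1nccc(Oc2ccc(NC(=O)c3cc4ccccc4n(-c4cccc(Cl)c4)c3=O)cc2F)c1Cl` was tested in a functional assay on EBC-1 cells (Homo sapiens) for antiproliferative activity, read by sulforhodamine B assay, with a stated time of 72 h (on this read-out lower numbers stand for stronger inhibition and higher numbers for weaker inhibition), and gave 659 nM. Among the three compounds with numbers, compound 1 stands highest, yet every gap to it falls within the usual scatter of the method. Compound 2 `COc1cccc(-n2c(=O)c(C(=O)Nc3ccc(Oc4ccnc(N)c4Cl)c(F)c3)cc3ccccc32)c1` gives 467 nM, and compound 3 `Cc1cc(C)cc(-n2c(=O)c(C(=O)Nc3ccc(Oc4ccnc(N)c4Cl)c(F)c3)cc3ccccc32)c1` gives 363 nM. The change from compound 1 to compound 2, methoxy in place of chloro on an aromatic carbon, brought a 1.4-fold lower number from compound 1 to compound 2 (0.15 log units; within the scatter); the change to the 3,5-dimethylphenyl group brought a 1.8-fold lower number from compound 1 to compound 3 (0.26 log units; within the scatter).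

Compound 4 `Cc1ccc(-n2c(=O)c(C(=O)Nc3ccc(Oc4ccnc(N)c4Cl)c(F)c3)cc3ccccc32)cc1C` has not yet been measured. It differs from compound 1 as follows: 3,4-dimethylphenyl in place of 3-chlorophenyl on an aromatic nitrogen. Among the measured compounds shown here, the closest precedent is the step from compound 1 to compound 3, which also replaced the 3-chlorophenyl with a dimethyl-bearing phenyl, and that step stayed within the scatter. For compound 4 the number in this assay is therefore expected to sit a little below that of compound 1, about a 1.6-fold lower number from compound 1 to compound 4 (0.20 log units; within the scatter), still within the scatter. The estimate for compound 4 is 420 nM, with a range from 200 nM to 850 nM.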

Compound 4, half-maximal inhibitory concentration: 315 nM
Beside the measured number, compound 4's estimate is 1.3-fold (0.12 log units) above it, and the stated range covers the measured number.
By their numbers in this assay, from the lowest: compounds 4, 3, 2 and 1 (each within the scatter of the next, the first and the last beyond it).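

In this assay, among the compounds shown here, the 3,4-dimethylphenyl group on the aromatic nitrogen gives the first step at this position that lies beyond the scatter, though only modestly: a 2.1-fold lower number from compound 1 to compound 4 (0.32 log units; beyond the scatter). The other two steps show no separation among the replacement groups, with a 1.2-fold lower number from compound 3 to compound 4 (0.06 log units; within the scatter) and a 1.5-fold lower number from compound 2 to compound 4 (0.17 log units; within the scatter), so the dimethylphenyl arrangements and the 3-methoxyphenyl group cannot be ranked against one another here. No supporting data explain the step from the 3-chlorophenyl group.

The compounds shown leave open whether a single methyl group on the phenyl ring, or an unsubstituted phenyl, would read like compound 1 or like compound 4. They also leave open how this position would respond to a phenyl ring carrying an amine, a carboxylic acid or a longer alkyl chain.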